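Sulfonyl for carbonyl on the ring nitrogen: an open question

The compounds below may be only part of what the source reports. "The series", "measured", "known", "first", "only" and "open" are said of these compounds alone.

Compound 1 `C=C(C)C(=O)N1N=C(c2ccc(-n3ccnc3)cc2)CC1c1ccc(N(C)C)cc1`: -3.7%
Compound 2 `CN(C)c1ccc(C2CC(c3ccc(-n4ccnc4)cc3)=NN2C(=O)c2ccc(F)cc2)cc1`: -3.5%
Compound 3 `CN(C)c1ccc(C2CC(c3ccc(-n4ccnc4)cc3)=NN2C(=O)c2cc(Cl)cc(Cl)c2)cc1`: 58.7%

In a functional assay on NCI-H1975 cells (Homo sapiens) for inhibition, read by sulforhodamine B assay, tested at 10 uM (on this read-out higher numbers stand for more inhibition at the one concentration tested (going by the name of the read-out) and lower numbers for less inhibition), compound 3 stands highest of the three numbers; the nearest is compound 2, and the step of a number 62.2 percentage points higher from compound 2 to compound 3 (beyond the scatter) lies beyond the scatter, as does the step of a number 62.4 percentage points higher from compound 1 to compound 3 (beyond the scatter). The step of a number 0.2 percentage points higher from compound 1 to compound 2 (within the scatter) stays within the scatter.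

Compound 4 `CN(C)c1ccc(C2CC(c3ccc(-n4ccnc4)cc3)=NN2S(=O)(=O)c2ccc([N+](=O)[O-])cc2)cc1` has not yet been measured. It differs from compound 3 at the group on an amine nitrogen in a ring: (4-nitrophenyl)sulfonyl in place of (3,5-dichlorophenyl)carbonyl on an amine nitrogen in a ring. For the measured compounds named here, the steps of a number 62.4 percentage points higher from compound 1 to compound 3 (beyond the scatter) and a number 62.2 percentage points higher from compound 2 to compound 3 (beyond the scatter) bear on this place, and both show that what sits on that ring nitrogen can shift the read-out by a large amount; yet no measured compound carries a sulfonyl there, nor a 4-nitrophenyl group. The only (3,5-dichlorophenyl)carbonyl compound is the one that inhibits, so a fall from compound 3 is expected, but with wide uncertainty. For compound 4 the expected result is 25% (range -5% to 55%), an expected step of a number 33.7 percentage points lower from compound 3 to compound 4 (beyond the scatter).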

Compound 4, a percentage reported as inhibition, at one concentration (the size of the read-out at that concentration, not a potency): 53%
For compound 4 the middle estimate is 28 percentage points below the measured one; the range from low to high includes it.
By their numbers in this assay, from the lowest: compounds 1 and 2 (each within the scatter of the next); then compounds 4 and 3 (each within the scatter of the next).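

In this assay, for the compounds shown here, the step of a number 5.7 percentage points lower from compound 3 to compound 4 (within the scatter) shows that a sulfonyl-linked aryl group can replace a carbonyl-linked one on this amine nitrogen in a ring with no difference beyond the scatter, so (3,5-dichlorophenyl)carbonyl is not the only group here that goes with inhibition. The steps of a number 56.5 percentage points higher from compound 2 to compound 4 (beyond the scatter) and a number 56.7 percentage points higher from compound 1 to compound 4 (beyond the scatter) place compound 4 with compound 3 and apart from the other two, so the split at this position does not run between carbonyl and sulfonyl: compound 1 and compound 2 carry a carbonyl, but so does compound 3. Nothing at hand explains why these two groups read alike.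

Compound 4 differs from compound 3 in both the linker and the aryl group, so the compounds shown leave open which of the two bears on the result; a (3,5-dichlorophenyl)sulfonyl group would separate them. From the compounds shown here alone, how a methylsulfonyl group, which has no aromatic ring, would read on this nitrogen also remains open.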